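The compounds below may be only part of what the source reports. "The series", "measured", "known", "first", "only" and "open" are said of these compounds alone.

In a functional assay on A549 cells (Homo sapiens) for cytotoxicity, read by MTT assay, with a stated time of 48 h (a higher number here means a weaker inhibitor, a lower number a stronger inhibitor), compound 1 (`O=C(O)CN1C(=O)/C(=C/c2nc3ccccc3n2Cc2ccc([N+](=O)[O-])cc2)SC1=S`) gives 11400 nM, while compound 2 (`Cc1ccc(Cn2c(/C=C3\SC(=S)N(CC(=O)O)C3=O)nc3ccccc32)cc1`) gives 3220 nM, the lower of the two numbers. Among the compounds with values here, the only measured step between them is a 3.5-fold lower number from compound 1 to compound 2 (0.55 log units; beyond the scatter), a modest change made by methyl in place of nitro on an aromatic carbon. Compound 3 (`O=C(O)CN1C(=O)/C(=C/c2nc3ccccc3n2Cc2cccc(F)c2)SC1=S`) has not yet been measured. Its structure departs from compound 2 as follows: 3-fluorophenyl in place of 4-methylphenyl on a saturated chain carbon bound to an aromatic nitrogen. In words, 3-fluorophenyl stands in place of 4-methylphenyl on a saturated chain carbon bound to an aromatic nitrogen, which also reads as 4-methylbenzyl to 3-fluorobenzyl. Within the data shown here, the one measured step bears on this change only in part, as it also alters a substituent on this aromatic ring, and no measured compound carries fluorine. Since compound 2 holds the lower number, a moderate rise is expected, smaller than a 3.5-fold lower number from compound 1 to compound 2 (0.55 log units; beyond the scatter). The expected change is a 1.7-fold higher number from compound 2 to compound 3 (0.23 log units; within the scatter), though it may prove to lie within the scatter. For compound 3 the estimated value is 5500 nM, with an expected range from 2000 nM to 14000 nM.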

Compound 3, half-maximal inhibitory concentration: 23200 nM
Estimate against measurement, compound 3: 4.2-fold (0.63 log units) below; measured number above the stated range.
By their numbers in this assay, from the lowest: compound 2; then compound 1; then compound 3.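

In this assay, the place on a saturated chain carbon bound to an aromatic nitrogen proves sensitive to a swap of groups of equal size in heavy atoms: 3-fluorophenyl in place of 4-methylphenyl gives a 7.2-fold higher number from compound 2 to compound 3 (0.86 log units; beyond the scatter). The same new group also compares unfavourably with the nitro-bearing group, with a 2.0-fold higher number from compound 1 to compound 3 (0.31 log units; beyond the scatter), so the three benzyl groups now stand in a clear order, from 4-methylbenzyl with the lowest number, through 4-nitrobenzyl, to 3-fluorobenzyl with the highest. The leaving and entering groups match in their counts of donors, acceptors and charge, so those counts do not separate them, and nothing available explains the rise in the number.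

The change in compound 3 alters both the substituent and its place on the ring, so the compounds shown cannot say which of the two accounts for the higher number. Also open, going by these compounds, is how an unsubstituted phenyl, a chlorophenyl or a methoxyphenyl group would fall within this order at the same place on the shared core.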